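The compounds below may be only part of what the source reports. "The series", "measured", "known", "first", "only" and "open" are said of these compounds alone.

Measured so far in a functional assay on HeLa cells (Homo sapiens) for antiproliferative activity, with a stated time of 24 h; a lower number here means a stronger inhibitor, a higher number a weaker inhibitor:
compound 1, `NC(=O)c1c(NC(=O)c2ccccc2Cl)sc2c1CCN(C(=S)Nc1ccccc1C(F)(F)F)C2`, gives 26700 nM;
compound 2, `NC(=O)c1c(NC(=O)c2ccccc2Br)sc2c1CCN(C(=S)Nc1ccccc1Cl)C2`, gives 46900 nM;
compound 3, `NC(=O)c1c(NC(=O)c2ccccc2Br)sc2c1CCN(C(=S)Nc1ccccc1Br)C2`, gives 24700 nM.

Compound 3 carries the lowest of the three numbers, yet its gaps to compound 1 and to compound 2 both lie within the scatter, so no ranking follows. Compound 4, `NC(=O)c1c(NC(=O)c2ccccc2Br)sc2c1CCN(C(=S)Nc1ccccc1C(F)(F)F)C2`, differs from compound 3 by trifluoromethyl in place of bromo on an aromatic carbon. Going by the values given here, the only single-point step measured, a 1.9-fold lower number from compound 2 to compound 3 (0.28 log units; within the scatter), exchanges chloro for bromo on an aromatic carbon and stays within the scatter; compound 1 and compound 3, which differ in two places and between them cover this trifluoromethyl group, give values within the scatter of each other. For compound 4 no shift beyond the scatter is expected in this assay, a 1.1-fold higher number from compound 3 to compound 4 (0.02 log units; within the scatter). Compound 4 is estimated at 26000 nM, range 12000 nM to 55000 nM.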

Compound 4, half-maximal inhibitory concentration: 39600 nM
Compound 4: middle estimate off by 1.5-fold (0.18 log units), on the low side, and the stated range covers the measured number.
By their numbers in this assay, from the lowest: compounds 3, 1, 4 and 2 (each within the scatter of the next).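

In this assay, trifluoromethyl on this aromatic carbon, ortho to a large group, stays within the scatter against both halogens: a 1.6-fold higher number from compound 3 to compound 4 (0.20 log units; within the scatter) for bromo and a 1.2-fold lower number from compound 2 to compound 4 (0.07 log units; within the scatter) for chloro. Bromo in place of chloro now has a second reading, a 1.5-fold higher number from compound 1 to compound 4 (0.17 log units; within the scatter), and although each single step stays within the scatter, the two do not agree: the same change on two cores in this assay, a 1.9-fold lower number (0.28 log units; within the scatter) from compound 2 to compound 3 and a 1.5-fold higher number (0.17 log units; within the scatter) from compound 1 to compound 4, 2.8-fold (0.45 log units) apart, beyond the scatter of two such steps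

As far as these compounds go, whether an amine, a carboxylic acid or a longer chain at this position would shift the number beyond the scatter stays open. So does whether the gap between the two cores holds on further cores.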